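The source may hold more compounds than are shown below. What is called first, only, known or untested is meant among the compounds shown, and "the series" means these compounds.

Working notes on the series. Among the compounds with values here, compound 1 `CC(=O)NCc1cccc(Cn2nc(NS(=O)(=O)c3ccc(Cl)s3)c3c(C(C)=O)cccc32)c1` and compound 2 `CC(=O)NCc1cccc(Cn2nc(NS(=O)(=O)c3ccc(Cl)s3)c3c(C(C)(C)O)cccc32)c1` share the core carrying the sulfonamide and the benzyl-linked acetamide; in a functional assay on CHO cells for antagonist activity at C-C chemokine receptor type 4 (Homo sapiens), read by GTPgammaS binding (on this read-out higher numbers stand for weaker inhibition and lower numbers for stronger inhibition), compound 1 gives 100 nM and compound 2 gives 100 nM, so the only measured single change, no change at the digits printed from compound 1 to compound 2 (within the scatter), leaves the number where it was. Compound 3 `COc1cccc2c1c(NS(=O)(=O)c1ccc(Cl)s1)nn2Cc1cccc(CNC(=O)C2CCCO2)c1` differs in the core substituent and in the amide, and in this assay compound 3 gives 39.8 nM, the lowest of the three numbers; its gap to compound 1 and to compound 2 lies beyond the scatter in each case, so compound 3 is the most potent of the measured set. Compound 4 `COc1cccc2c1c(NS(=O)(=O)c1ccc(Cl)s1)nn2Cc1cccc(CNC(=O)[C@@H]2CCCCN2)c1` is the next member, differing from compound 3 only at the amide: piperidin-2-yl in place of oxolan-2-yl on a carbonyl carbon. Within the data shown here, no measured step touches this amide position; the one step on record, from compound 1 to compound 2, sits elsewhere on the core and shows no movement. With nothing to argue for a shift, the expected step of a 1.0-fold higher number from compound 3 to compound 4 (0.00 log units; within the scatter) is none beyond the scatter, and compound 4 is estimated at 40 nM in this assay, within 15 nM to 120 nM.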

Compound 4, half-maximal inhibitory concentration in the C-C chemokine receptor type 4 assay: 15.9 nM
Compound 4: middle estimate off by 2.5-fold (0.40 log units), on the high side; the range from low to high includes it.
By their numbers in the C-C chemokine receptor type 4 assay, from the lowest: compound 4; then compound 3; then compounds 1 and 2 (each within the scatter of the next).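

Within the data shown here, in the C-C chemokine receptor type 4 assay, piperidin-2-yl in place of oxolan-2-yl on a carbonyl carbon gives a 2.5-fold lower number from compound 3 to compound 4 (0.40 log units; beyond the scatter), so the number moves at this amide position, unlike in the one earlier step, which sat elsewhere on the core and stayed within the scatter. In a physicochemical assay for solubility, read by chemiluminescence, measured as kinetic solubility (on this read-out lower numbers stand for lower solubility and higher numbers for higher solubility), compound 3 gives >= 153 ug/mL, which is a limit of the assay and not a number. In the physicochemical assay compound 4 gives >= 220 ug/mL, which is likewise a limit.

The step between these two limits cannot be read. The change in the amide alters ring size, ring hetero atom, hydrogen-bond donor count and defined stereocentre all at once, leaving open which of these goes with the step; pyrrolidin-2-yl and oxan-2-yl on the same carbonyl carbon would begin to separate them.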